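The source may report more compounds than this note shows. Statements on the series, on what has been measured and on what is new or still open speak of the compounds shown alone.

Measured in an ADME assay on Huh-7 cells (Homo sapiens) for cytotoxicity, read by MTT assay, with a stated time of 96 h; on this read-out higher numbers stand for lower toxicity in this test and lower numbers for higher toxicity in this test:
- compound 1 `COc1cc(NCc2scnc2C)ccc1-c1cnco1`: 58500 nM
- compound 2 `COc1cc(NCc2cncs2)ccc1-c1cnco1`: 68900 nM

In this assay compound 2 stands at 68900 nM, level with compound 1 once the scatter is considered. Within the data shown here, the single measured step is a 1.2-fold higher number from compound 1 to compound 2 (0.07 log units; within the scatter). Compound 3 `COc1cc(NCc2ccc(Br)s2)ccc1-c1cnco1` keeps the shared core but carries 5-bromothiophen-2-yl in place of 1,3-thiazol-5-yl on a saturated chain carbon bound to a nitrogen on an aromatic ring. The measured step only exchanges methyl for hydrogen on an aromatic carbon, so it bears on this change only weakly. Among the measured compounds shown here, no measured pair exchanges the whole ring, which leaves the direction uncertain. A modest move toward a lower number in this assay is tentatively expected, and the expected step is a 1.7-fold lower number from compound 2 to compound 3 (0.24 log units; within the scatter). For compound 3 the estimated value is 40000 nM, with an expected range from 15000 nM to 90000 nM.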

Compound 3, half-maximal cytotoxic concentration: 39400 nM
Compound 3: the middle estimate sits 1.0-fold (0.01 log units) above what was measured; the measured number falls inside the stated range.
By their numbers in this assay, from the lowest: compounds 3, 1 and 2 (each within the scatter of the next).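

In this assay the place on a saturated chain carbon bound to a nitrogen on an aromatic ring now takes a whole ring exchange, where the earlier pair changed only a methyl. Putting 5-bromothiophen-2-yl in place of 1,3-thiazol-5-yl gives a 1.7-fold lower number from compound 2 to compound 3 (0.24 log units; within the scatter) and, set against the 4-methyl-1,3-thiazol-5-yl ring, gives a 1.5-fold lower number from compound 1 to compound 3 (0.17 log units; within the scatter) so the read-out does not separate the three compounds, even with a bromine entering and a ring nitrogen leaving. Nothing at hand accounts for this result.

The compounds shown leave open how the bromine and the change of ring each count on their own. They also leave open whether an amine or a carboxylic acid in place of the bromine would carry the number beyond the scatter.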